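This account rests on a few compounds, and the source may have more. Where it says the series, first, only, none or still open, it means among the compounds named here.

Of the compounds shown here, three of one series have been tested so far. Compound 3, with the structure `O=C1/C(=C/c2ccccc2F)CN(Cc2cn(Cc3ccc(F)cc3)nn2)C/C1=C\c1ccccc1F`, and compound 1, with the structure `O=C1/C(=C/c2ccccc2F)CN(Cc2cn(Cc3cccc(Cl)c3)nn2)C/C1=C\c1ccccc1F`, share a core and differ only in one group. In a functional assay on MDA-MB-231 cells (Homo sapiens) for cytotoxicity, read by MTT assay, with a stated time of 24 h (a higher number here means a weaker inhibitor, a lower number a stronger inhibitor), compound 3 gives 10000 nM, and compound 1 gives 12000 nM. The change between them is 3-chlorophenyl in place of 4-fluorophenyl on a saturated chain carbon bound to an aromatic nitrogen and it made a step of a 1.2-fold higher number from compound 3 to compound 1 (0.08 log units; within the scatter). Compound 2, with the structure `O=C1/C(=C/c2ccccc2F)CN(C(=S)SCc2cn(Cc3ccc(F)cc3)nn2)C/C1=C\c1ccccc1F`, carries a different core; how its core differs from that of compound 3 is not broken down here. In this assay compound 2 gives 58800 nM, the highest of the three numbers, and its gap to compound 1 and to compound 3 lies beyond the scatter.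

Compound 4, with the structure `O=C1/C(=C/c2ccccc2F)CN(C(=S)SCc2cn(Cc3cccc(Cl)c3)nn2)C/C1=C\c1ccccc1F`, has not yet been measured. It is related to compound 2 by 3-chlorophenyl in place of 4-fluorophenyl on a saturated chain carbon bound to an aromatic nitrogen, the same change that takes compound 3 to compound 1, at the same place. Because the earlier step was a 1.2-fold higher number from compound 3 to compound 1 (0.08 log units; within the scatter) and fell within the scatter, compound 4 is expected to sit close to compound 2, with a step of about a 1.1-fold higher number from compound 2 to compound 4 (0.04 log units; within the scatter) anticipated. On that basis compound 4 is estimated at 65000 nM in this assay, with an expected range from 30000 nM to 140000 nM.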

Compound 4, half-maximal inhibitory concentration: > 100000 nM
Compound 4: only a limit was reported; the forecaster's own chance of this, stated with the estimate: 10%; middle value at least 1.5-fold (0.18 log units) from the limit.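

In this assay compound 4 gives > 100000 nM, which is a limit of the assay and not a number. The step that can be read is an at least 1.7-fold higher number from compound 2 to compound 4 (0.23 log units; that floor lies within the scatter); it is a floor and gives no size for the change from 4-fluorobenzyl to 3-chlorobenzyl on the core of compound 2. This shows that the change was tested on two cores and that the step on the second core has only a lower bound, but it does not show whether the change carries over with the same size or behaves differently there: the same change on two cores in this assay, a 1.2-fold higher number (0.08 log units; within the scatter) from compound 3 to compound 1 and an at least 1.7-fold higher number (0.23 log units; that floor lies within the scatter) from compound 2 to compound 4; the limit leaves it open whether they differ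

The compounds shown leave open whether other groups in this place, such as an unsubstituted phenyl, a 4-chlorophenyl, a 3-fluorophenyl or a methoxyphenyl, would give matching steps on the two cores. They also leave open how far the reading for compound 4 lies from the limit, so this single pair on the core of compound 2 cannot fix the size of the step: the limit of > 100000 nM in this assay, at which 1 of the 4 values shown sits.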